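Oxime ether tail: methyl ether to free hydroxyl

A few compounds are considered here, and "the series" means these few. Any claim that something is new, unique, unknown or untested is made for them only; others in the source may bear on it.

Measured so far:
- compound 1 `COCCO/N=C/c1c(N)ncnc1Oc1ccc2[nH]c(C)cc2c1F`: 308 nM
- compound 2 `CO/N=C/c1c(N)ncnc1Oc1ccc2[nH]ccc2c1`: 1870 nM

In a functional assay on HeLa cells (Homo sapiens) for antiproliferative activity (on this read-out higher numbers stand for weaker inhibition and lower numbers for stronger inhibition), compound 1 gives 308 nM and holds the lower of the two numbers, meaning the stronger inhibition. Compound 2 `CO/N=C/c1c(N)ncnc1Oc1ccc2[nH]ccc2c1` gives 1870 nM in this assay; the gap between the two lies beyond the usual scatter, but the compounds differ in several places at once, so no single structural cause can be read from it.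

Compound 3 `Cc1cc2c(F)c(Oc3ncnc(N)c3/C=N/OCCO)ccc2[nH]1` has not been measured yet. It differs from compound 1 in one place only: hydrogen in place of methyl on an oxygen on a saturated carbon. Nothing measured here isolates this kind of change, so the direction of its effect is open. With only the tail of the chain altered, the step of a 1.4-fold higher number from compound 1 to compound 3 (0.13 log units; within the scatter) is expected to stay small, at most a little beyond the scatter. Compound 3 is therefore estimated at 420 nM in this assay, within a range of 150 nM to 1200 nM.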

Compound 3, half-maximal inhibitory concentration: 406 nM
Compound 3: the middle estimate sits 1.0-fold (0.01 log units) above what was measured, within the range that was stated.
By their numbers in this assay, from the lowest: compounds 1 and 3 (each within the scatter of the next); then compound 2.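

Going from the 2-methoxyethyl tail to the 2-hydroxyethyl tail in this assay gives a 1.3-fold higher number from compound 1 to compound 3 (0.12 log units; within the scatter), so the two compounds cannot be told apart on this read-out. Within the data shown here, this is the first comparison here that isolates a single change, and it shows that hydrogen can stand in place of methyl on this oxygen at the end of the chain without a difference beyond the scatter. No measurement of any other property bears on this result, so the numbers offer no explanation for it.

As far as these compounds go, whether the chain end accepts something larger or different stays open, such as an amine, a carboxylic acid or a longer chain. Compound 2 differs from compound 1 in several places at once, so the effect of each of those differences cannot be read from these numbers.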